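One aromatic group swapped in a level series

The source may report more compounds than this note shows. Statements on the series, on what has been measured and on what is new or still open speak of the compounds shown alone.

In an ADME assay on HEK293 cells (Homo sapiens) for cytotoxicity (a higher number here means a weaker inhibitor, a lower number a stronger inhibitor), compound 1 `CCCCCCCCCCCCCCNC(=O)[C@H](CO)/N=C/c1ccc(OC)cc1` gives 81700 nM. Compound 2 `CCCCCCCCCCCCCCNC(=O)[C@H](CO)/N=C/c1ccccc1OC` gives 79200 nM, and compound 3 `CCCCCCCCCCCCCCNC(=O)[C@H](CO)/N=C/c1cccc([N+](=O)[O-])c1` gives 82700 nM, so compound 1 stands within the scatter of both. Compound 4 `CCCCCCCCCCCCCCNC(=O)[C@H](CO)/N=C/c1cccc(Cl)c1`, not yet measured, differs from compound 1 as follows: 3-chlorophenyl in place of 4-methoxyphenyl on a carbon with a double bond to nitrogen. Two measured changes at this same place bear on it: a 1.0-fold lower number from compound 1 to compound 2 (0.01 log units; within the scatter) and a 1.0-fold higher number from compound 1 to compound 3 (0.01 log units; within the scatter). The second also puts a new group in place of 4-methoxyphenyl, and neither step goes beyond the scatter. No step beyond the scatter is therefore expected here, and the estimated step is a 1.0-fold lower number from compound 1 to compound 4 (0.01 log units; within the scatter). For compound 4 the estimated value is 80000 nM, with an expected range of 55000 nM to 115000 nM.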

Compound 4, half-maximal inhibitory concentration: 77000 nM
For compound 4 the middle estimate is 1.0-fold (0.02 log units) above the measured one; measured number inside the range.
By their numbers in this assay, from the lowest: compounds 4, 2, 1 and 3 (each within the scatter of the next).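

In this assay, the chloro compound falls in with the rest of the series: a 1.1-fold lower number from compound 1 to compound 4 (0.03 log units; within the scatter), a 1.1-fold lower number from compound 3 to compound 4 (0.03 log units; within the scatter) and a 1.0-fold lower number from compound 2 to compound 4 (0.01 log units; within the scatter). Unlike 4-methoxyphenyl, 3-chlorophenyl has no hydrogen-bond acceptor, and even that difference leaves the step within the scatter. Nothing measured here offers a reason for this flat behaviour.

On these data alone, whether an amine or a carboxylic acid on the aromatic ring would give a step beyond the scatter remains open. So does the effect of a shorter chain in the shared core.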